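Aniline substituent changes and solubility in the amide series

The source may hold more compounds than are shown below. What is called first, only, known or untested is meant among the compounds shown, and "the series" means these compounds.

Measured compounds:
compound 1 `O=C(NCC1CCOCC1)c1cnc(Nc2cc(Cl)cc(Cl)c2)cc1C1CC1`; in a physicochemical assay for solubility, at pH 7.4 (on this read-out higher numbers stand for higher solubility and lower numbers for lower solubility), compound 1 gives 7 ug/mL
compound 2 `Cc1cccc(Nc2cc(C3CC3)c(C(=O)NCC3CCOCC3)cn2)c1`; in this assay compound 2 gives 26 ug/mL
compound 3 `O=C(NCC1CCOCC1)c1cnc(Nc2cccc(F)c2)cc1C1CC1`; in this assay compound 3 gives 125 ug/mL

Compound 3 stands highest of the three numbers in this assay. The gaps to the other two are beyond the scatter: a 4.8-fold higher number from compound 2 to compound 3 (0.68 log units; beyond the scatter) and an 18-fold higher number from compound 1 to compound 3 (1.25 log units; beyond the scatter). Between the two lower compounds, a 3.7-fold higher number from compound 1 to compound 2 (0.57 log units; beyond the scatter). All three measured steps change the substituents on the phenyl ring attached to the nitrogen, and all three moved the number.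

Compound 4 `N#Cc1cccc(Nc2cc(C3CC3)c(C(=O)NCC3CCOCC3)cn2)c1` differs from compound 3 in one place: cyano in place of fluoro on an aromatic carbon. Going by the values given here, none of the measured steps exchanges fluoro for cyano, so the measured data give no direct precedent for this change, neither for its direction nor for its size. Among the compounds with values here, the only guide is that substituent changes on this ring have so far shifted the number by modest to large amounts. Within the data shown here, with no precedent pointing either way, a step within the scatter is expected. Compound 4 is expected at about 110 ug/mL, with a range from 35 ug/mL to 350 ug/mL, that is, an expected 1.1-fold lower number from compound 3 to compound 4 (0.06 log units; within the scatter).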

Compound 4, solubility: 4 ug/mL
Estimate against measurement, compound 4: 28-fold (1.44 log units) above, outside the stated range (below it).
By their numbers in this assay, from the lowest: compounds 4 and 1 (each within the scatter of the next); then compound 2; then compound 3.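

Going by these compounds alone, at this aromatic carbon, cyano in place of fluoro gives a 31-fold lower number from compound 3 to compound 4 (1.49 log units; beyond the scatter) in this assay, the largest single step so far, so a change of one group on this ring can span the whole spread of numbers seen. The 3-cyanophenyl group, with one substituent, also sits within the scatter of the 3,5-dichlorophenyl group, with a 1.8-fold lower number from compound 1 to compound 4 (0.24 log units; within the scatter), while the exchange of methyl for cyano gives a 6.5-fold lower number from compound 2 to compound 4 (0.81 log units; beyond the scatter), which places cyano well under both fluoro and methyl at this position. Nothing shown bears on why this exchange moves the number so far.

As far as these compounds go, whether a methoxy group, an aminomethyl group or a carboxylic acid on this carbon would give a number nearer compound 3 or nearer compound 4 remains open. Also open, from the compounds shown here alone, is whether the cyano step keeps its size with a different amide side chain on the shared core.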